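A few compounds are considered here, and "the series" means these few. Any claim that something is new, unique, unknown or untested is made for them only; others in the source may bear on it.

Compound 3, `COc1cc(OC)c(/C=C(/SCc2ccc(F)cc2)C(=O)c2ccc(Cl)cc2)c(OC)c1`, gives 10000 nM in a functional assay on DU-145 cells (Homo sapiens) for inhibition, read by trypan blue exclusion, with a stated time of 96 h; a lower number here means a stronger inhibitor of growth, a higher number a weaker inhibitor of growth. Compound 1, `COc1cc(OC)c(/C=C(/SCc2ccc(Cl)c(Cl)c2)C(=O)c2ccc(Cl)cc2)c(OC)c1`, gives 10000 nM in this assay, and compound 2, `Cc1ccc(CS/C(=C/c2ccccc2F)C(=O)c2ccc(Cl)cc2)cc1`, gives 10000 nM. The one measured step, no change at the digits printed from compound 1 to compound 3 (within the scatter), shows nothing beyond the scatter, so compound 3 stands level with both compounds on the numbers shown. Compound 4, `COc1cc(OC)c(/C=C(\C(=O)c2ccc(Cl)cc2)S(=O)(=O)c2ccc(Br)cc2)c(OC)c1`, differs from compound 3 by (4-bromophenyl)sulfonyl in place of (4-fluorobenzyl)sulfanyl on a double-bonded chain carbon bound to a carbonyl carbon and a double-bonded chain carbon. Among the compounds with values here, no measured step touches this position, and the only measured step concerns a different place, so nothing in the data points to a shift in either direction; the account expects no step beyond the scatter. The expected step is no change at the digits printed from compound 3 to compound 4 (within the scatter). Compound 4 is therefore estimated at 10000 nM, ranging from 4000 nM to 25000 nM.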

Compound 4, concentration for 50% growth inhibition: > 100000 nM
Compound 4: a limit, no number; the forecaster's own chance of this, stated with the estimate: 40%; middle value at least 10-fold (1.00 log units) away from the limit.
By their numbers in this assay, from the lowest: compounds 1, 2 and 3 (each within the scatter of the next). At a limit, above all of these: compound 4.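

At the position on a double-bonded chain carbon bound to a carbonyl carbon and a double-bonded chain carbon, the change to (4-bromophenyl)sulfonyl gives an at least 10-fold higher number from compound 3 to compound 4 (1.00 log units; beyond the scatter) and an at least 10-fold higher number from compound 1 to compound 4 (1.00 log units; beyond the scatter). Within the data shown here, the earlier compounds showed no movement beyond the scatter, so this is the first sign that the group here matters in this assay, and the shift is toward weaker growth inhibition. The reading for compound 4 is a limit of the assay, not a number: the limit of > 100000 nM in this assay, at which 1 of the 4 values shown sits.

The whole group changes at once, so the compounds shown leave the sulfonyl, the bromine and the lost chain carbon unseparated. They also leave open whether (4-fluorobenzyl)sulfonyl or an amine at this place would give a lower number.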